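Swapping an aryl amide cap for a furan

This account rests on a few compounds, and the source may have more. Where it says the series, first, only, none or still open, it means among the compounds named here.

Among the compounds with values here, compound 2 `O=C(Nc1nn(-c2ccccc2)c(=O)c2ccccc12)c1ccc(Cl)cc1` gives 17% in an assay on CHO cells for displacement of a labelled ligand from adenosine receptor A3 (Homo sapiens), tested at 1 uM (a lower number here means less inhibition, a higher number more inhibition at the concentration tested (going by the name of the read-out)), the higher of the two numbers measured so far. Within the data shown here, compound 1 `CC(=O)Nc1nn(-c2ccccc2)c(=O)c2ccccc12` gives 0% in this assay, and the only step seen is a number 17 percentage points higher from compound 1 to compound 2 (beyond the scatter), made by placing 4-chlorophenyl instead of methyl on the carbonyl carbon. Compound 3 `O=C(Nc1nn(-c2ccccc2)c(=O)c2ccccc12)c1ccco1` changes that same group: furan-2-yl in place of 4-chlorophenyl on a carbonyl carbon. Since furan-2-yl is smaller than 4-chlorophenyl yet larger than methyl, a modest loss within or near the scatter is expected, a number 7 percentage points lower from compound 2 to compound 3 (within the scatter). Compound 3 is therefore estimated at 10%, between 0% and 28%.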

Compound 3, a percentage reported as inhibition, at one concentration (the size of the read-out at that concentration, not a potency): 8%
For compound 3 the middle estimate is 2 percentage points above the measured one, and the stated range covers the measured number.
By their numbers in this assay, from the lowest: compounds 1, 3 and 2 (each within the scatter of the next, the first and the last beyond it).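

In this assay furan-2-yl in place of 4-chlorophenyl gives a number 9 percentage points lower from compound 2 to compound 3 (within the scatter) while furan-2-yl in place of methyl gives a number 8 percentage points higher from compound 1 to compound 3 (within the scatter) and so the furan cap cannot be told apart from either of the other two caps, although those two differ clearly from each other. Nothing measured here explains this result.

As far as these compounds go, it remains open whether a longer alkyl chain or a naphthyl group on this carbonyl carbon would clearly exceed compound 2 at the concentration tested.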